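Trimming the Acetamide: Expectation for Compound 4

The source may report more compounds than this note shows. Statements on the series, on what has been measured and on what is new or still open speak of the compounds shown alone.

Compound 1 `O=S(=O)(NCC1CCN(CCCc2c[nH]c3ccc(-n4cnnc4)cc23)CC1)c1ccccc1` gives 12 nM in an assay on CHO cells for agonist activity at 5-hydroxytryptamine receptor 1D (Homo sapiens), read by GTPgammaS binding; a lower number here means that less compound is needed, a higher number that more compound is needed for the effect.
Compound 2 `CC(=O)Nc1ccc([C@H](C)NCC2CCN(CCCc3c[nH]c4ccc(-n5cnnc5)cc34)CC2)cc1` gives 3 nM in this assay.
Compound 3 `CC(=O)Nc1ccc(CNC2CCN(CCCc3c[nH]c4ccc(-n5cnnc5)cc34)CC2)cc1` gives 5 nM in this assay.

Compound 3 stands second highest of the three numbers: it sits within the scatter of compound 2, while its gap to compound 1 lies beyond the scatter. Compound 4 `C[C@@H](NC1CCN(CCCc2c[nH]c3ccc(-n4cnnc4)cc23)CC1)c1ccccc1` differs from compound 3 by 1-phenylethyl in place of 4-acetamidobenzyl on an amine nitrogen. Among the measured compounds shown here, no measured pair isolates this change. For the measured compounds named here, the one measured step, a 4.0-fold lower number from compound 1 to compound 2 (0.60 log units; beyond the scatter), concerns a different exchange on the amine nitrogen and arrives at a group carrying an acetamide; compounds 2 and 3 both carry that acetamide and both give low numbers. With the acetamide removed in compound 4, a modest move toward a higher number is expected, a 1.6-fold higher number from compound 3 to compound 4 (0.20 log units; within the scatter). Compound 4 is therefore estimated at 8 nM, with a range from 3 nM to 25 nM.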

Compound 4, half-maximal effective concentration: 13 nM
For compound 4 the middle estimate is 1.6-fold (0.21 log units) below the measured one, and the stated range covers the measured number.
By their numbers in this assay, from the lowest: compounds 2 and 3 (each within the scatter of the next); then compounds 1 and 4 (each within the scatter of the next).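

In this assay, 1-phenylethyl in place of 4-acetamidobenzyl on this amine nitrogen gives a 2.6-fold higher number from compound 3 to compound 4 (0.41 log units; beyond the scatter), the first measured sign that this exchange costs something here, though a modest amount. The change of ((phenylsulfonyl)amino)methyl to (1-phenylethyl)amino on the saturated ring carbon gives a 1.1-fold higher number from compound 1 to compound 4 (0.03 log units; within the scatter), so these two groups are not told apart. Nothing available accounts for either step. Still open, going by these compounds, is how much of the first step follows the lost acetamide and how much the added methyl, which a plain benzyl group on this nitrogen would separate. On these data alone, the opposite stereocentre of 1-phenylethyl also remains unknown.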